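Sulfonamide nitrogen substituent and potency in this series

The compounds below may be only part of what the source reports. "The series", "measured", "known", "first", "only" and "open" are said of these compounds alone.

Working notes. All three measured compounds share the core of compound 1 `CC1(C)C=C(n2ccccc2=O)c2cc(S(=O)(=O)N=[N+]=[N-])ccc2O1` and differ only at the sulfonyl group. In a functional assay with Rattus norvegicus as the target (on this read-out higher numbers stand for an effect only at larger amounts of compound and lower numbers for an effect already at smaller amounts), compound 1 gives 204 nM. Compound 2 `CC1(C)C=C(n2ccccc2=O)c2cc(S(=O)(=O)NCCO)ccc2O1` gives 1000 nM and stands with the highest number of the three, a position set by the steps of a 4.9-fold higher number from compound 1 to compound 2 (0.69 log units; beyond the scatter) and a 76-fold lower number from compound 2 to compound 3 (1.88 log units; beyond the scatter). Compound 3 `CC1(C)C=C(n2ccccc2=O)c2cc(S(=O)(=O)Nc3ccccc3)ccc2O1` gives 13.2 nM, and the step of a 15-fold lower number from compound 1 to compound 3 (1.19 log units; beyond the scatter) places it well apart from compound 1 as well.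

Compound 4 `CC1(C)C=C(n2ccccc2=O)c2cc(S(=O)(=O)Nc3ccc([N+](=O)[O-])cc3)ccc2O1` is not yet measured. Relative to compound 2 the change is 4-nitrophenyl in place of 2-hydroxyethyl on a sulfonamide nitrogen. Within the data shown here, the step that bears on this most directly is the one from compound 2 to compound 3, where a phenyl on the same nitrogen brought a large fall in the number; compound 4 carries a 4-nitrophenyl on that nitrogen and is expected to follow the same direction, with some allowance for the nitro group being untested here. The number for compound 4 is therefore expected to be 20 nM, within a range of 5 nM to 80 nM. That estimate means a step of a 50-fold lower number from compound 2 to compound 4 (1.70 log units; beyond the scatter).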

Compound 4, half-maximal effective concentration: 10200 nM
Compound 4: middle estimate off by 510-fold (2.71 log units), on the low side; measured number outside the range, above it.
By their numbers in this assay, from the lowest: compound 3; then compound 1; then compound 2; then compound 4.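

Phenyl on the sulfonamide nitrogen does not by itself secure a low number in this assay: nitro in place of hydrogen on an aromatic carbon of that ring gives the largest step in the series (a 770-fold higher number from compound 3 to compound 4 (2.89 log units; beyond the scatter)). With 4-nitrophenyl, the order seen with phenyl is reversed: the aryl compound now stands higher than the 2-hydroxyethyl compound (a 10-fold higher number from compound 2 to compound 4 (1.01 log units; beyond the scatter)) and higher than the sulfonyl azide (a 50-fold higher number from compound 1 to compound 4 (1.70 log units; beyond the scatter)). Nothing available explains this reversal.

As far as these compounds go, it remains open whether the rise is specific to nitro or would also appear with a methoxy group, a chlorine atom or an amine on the same ring. A benzyl group or a longer alkyl chain on the sulfonamide nitrogen would show how far the low number depends on the nitrogen carrying an unsubstituted phenyl ring directly.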